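Swapping 2-hydroxyethyl for cyclobutyl on an amide-type nitrogen

The compounds below may be only part of what the source reports. "The series", "measured", "known", "first", "only" and "open" are said of these compounds alone.

Compound 1 `CCC[C@@H]1C[C@@H](c2ccc(Cl)c(Cl)c2)[C@H](NC(=O)c2cc(-c3c(Cl)cnn3C)c(Cl)o2)CN1` gives "not determined" (no result reported)
Compound 2 `Cn1ncc(Cl)c1-c1cc(C(=O)N[C@@H]2CN[C@H](CC(=O)NC3CC3)C[C@H]2c2ccc(Cl)c(Cl)c2)oc1Cl` gives 190 nM
Compound 3 `Cn1ncc(Cl)c1-c1cc(C(=O)N[C@@H]2CN[C@H](CC(=O)NCCO)C[C@H]2c2ccc(Cl)c(Cl)c2)oc1Cl` gives 40 nM

All three entries come from a functional assay on LNCaP cells (Homo sapiens) for antiproliferative activity (a lower number here means a stronger inhibitor, a higher number a weaker inhibitor), and compound 1 has no number to compare. Compound 3 therefore holds the lower of the two numbers available, and its gap to compound 2 lies beyond the scatter. The next analogue, compound 4 `Cn1ncc(Cl)c1-c1cc(C(=O)N[C@@H]2CN[C@H](CC(=O)NC3CCC3)C[C@H]2c2ccc(Cl)c(Cl)c2)oc1Cl`, has not yet been measured. Its change from compound 3 is cyclobutyl in place of 2-hydroxyethyl on an amide-type nitrogen and it sits on an amide-type nitrogen whose other neighbour is the carbonyl carbon, so cyclobutyl takes the place of 2-hydroxyethyl.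

Among the measured compounds shown here, only one measured step bears on this change. It is a 4.8-fold lower number from compound 2 to compound 3 (0.68 log units; beyond the scatter) and comes from 2-hydroxyethyl replacing cyclopropyl on the same nitrogen. Compound 4 runs the other way, from 2-hydroxyethyl to a ring of carbon only, although no cyclobutyl amide has a number yet. A step of similar size towards a higher number is therefore expected, with compound 2 at 190 nM as the nearest guide. The estimated step is a 4.3-fold higher number from compound 3 to compound 4 (0.63 log units; beyond the scatter) in this assay and would make the compound clearly weaker. The expected value for compound 4 is 170 nM, with an estimated range from 70 nM to 420 nM.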

Compound 4, half-maximal inhibitory concentration: 80 nM
For compound 4 the middle estimate is 2.1-fold (0.33 log units) above the measured one; the range from low to high includes it.
By their numbers in this assay, from the lowest: compounds 3 and 4 (each within the scatter of the next); then compound 2.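

In this assay, cyclobutyl on the amide-type nitrogen gives a 2.0-fold higher number from compound 3 to compound 4 (0.30 log units; within the scatter), so at this place a ring of carbon only, with 0 hydrogen-bond donors and 0 hydrogen-bond acceptors, is not separated from 2-hydroxyethyl. The two carbon rings, however, are separated: cyclobutyl in place of cyclopropyl gives a 2.4-fold lower number from compound 2 to compound 4 (0.38 log units; beyond the scatter), a modest step that shows a change of ring size alone can be read at this nitrogen. The earlier step, a 4.8-fold lower number from compound 2 to compound 3 (0.68 log units; beyond the scatter), could have suggested that 2-hydroxyethyl stood apart from carbon rings in general, but among these three amides only compound 2 stands apart, while compound 3 and compound 4 lie within the scatter of each other.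

Nothing measured here accounts for these differences among the three groups. Going by these compounds, it remains open whether a larger ring such as cyclopentyl, an unbranched chain such as n-butyl or a 2-methoxyethyl group on the same nitrogen would fall with compound 3 and compound 4 or with compound 2.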